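Series notes: hydrogen replacing chloro on the aryl imine

The source may hold more compounds than are shown below. What is called first, only, known or untested is meant among the compounds shown, and "the series" means these compounds.

Compound 2 `Clc1ccc(/C=N/c2sc3c(c2-c2nc4ccccc4s2)CCCC3)c(Cl)c1` is the point of departure. In an ADME assay on HepG2 cells (Homo sapiens) for cytotoxicity, read by MTT assay, with a stated time of 72 h (a higher number here means that more compound is tolerated, a lower number that less compound is tolerated), compound 2 gives 384 ug/mL, and compound 1 `Fc1ccccc1/C=N/c1sc2c(c1-c1nc3ccccc3s1)CCC2` gives 394 ug/mL in this assay, the two numbers lying within the usual scatter of each other, so neither stands apart. Compound 3 `Clc1ccccc1/C=N/c1sc2c(c1-c1nc3ccccc3s1)CCCC2` is not yet measured. The change from compound 2 to compound 3 is hydrogen in place of chloro on an aromatic carbon, a hydrogen in place of chloro on an aromatic carbon. For the measured compounds named here, no step between measured compounds shows what such a change does; the expected step of a 1.0-fold higher number from compound 2 to compound 3 (0.01 log units; within the scatter) is none beyond the scatter. Compound 3 is expected at 390 ug/mL, within 250 ug/mL to 550 ug/mL.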

Compound 3, half-maximal cytotoxic concentration: 370 ug/mL
Compound 3: the middle estimate sits 1.1-fold (0.02 log units) above what was measured, and the stated range covers the measured number.
By their numbers in this assay, from the lowest: compounds 3, 2 and 1 (each within the scatter of the next).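

In this assay, for the compounds shown here, the swap of 2,4-dichlorophenyl for 2-chlorophenyl reads as a 1.0-fold lower number from compound 2 to compound 3 (0.02 log units; within the scatter) and gives the first direct reading at this place, para to a large group. With the core held constant, compound 2 and compound 3 stand level, so the number seen does not depend on a chloro here. Nothing measured speaks to why this swap leaves the number within the scatter.

On these data alone, whether an amine, a carboxylic acid or a methoxy group at this place would move the number stays open. So does what hydrogen would do in place of the remaining chloro of 2-chlorophenyl.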